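This account rests on a few compounds, and the source may have more. Where it says the series, first, only, none or still open, it means among the compounds named here.

Compound 1, `Cc1n[nH]c2ccc(-c3nc4cnc(N5CCN(C)CC5)cn4c3Nc3ccc(I)cc3)cc12`, carries a 4-iodophenyl group on the amino nitrogen of the shared core. In a functional assay on MV4-11 cells (Homo sapiens) for inhibition, with a stated time of 120 h (a lower number here means a stronger inhibitor, a higher number a weaker inhibitor), compound 1 has no single number; its result there is given as "not determined" (no result reported), so it cannot be placed on the scale. The only measured point in the series is compound 2, `Cc1n[nH]c2ccc(-c3nc4cnc(N5CCN(C)CC5)cn4c3Nc3ccc(F)c(Cl)c3)cc12`, which carries a 3-chloro-4-fluorophenyl group on the same nitrogen; in this assay compound 2 gives 2850 nM.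

Compound 3, `Cc1n[nH]c2ccc(-c3nc4cnc(N5CCN(C)CC5)cn4c3Nc3ccc(Cl)cc3Cl)cc12`, differs from compound 1 by 2,4-dichlorophenyl in place of 4-iodophenyl on a nitrogen on an aromatic ring. With no value for compound 1, no direction or size can be stated for the step from compound 1 to compound 3 in this assay, and the estimate for compound 3 rests only on compound 2 and the resemblance of its two halogens on the phenyl ring.

Compound 3 is therefore expected to give about 3000 nM in this assay, with the range 800 nM to 12000 nM reflecting that a single halogen pattern, that of compound 2 with 2850 nM, is the sole anchor.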

Compound 3, half-maximal inhibitory concentration: 4720 nM
Compound 3: middle estimate off by 1.6-fold (0.20 log units), on the low side; the measured number falls inside the stated range.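

Replacing 3-chloro-4-fluorophenyl with 2,4-dichlorophenyl on a nitrogen on an aromatic ring gives, in this assay, a 1.7-fold higher number from compound 2 to compound 3 (0.22 log units; within the scatter). For the compounds shown here, this is the first comparison available at this position, and it shows that these two dihalogenated phenyl groups cannot be told apart in this read-out, so this change of halogens and their arrangement on the phenyl ring has no effect that can be distinguished from the scatter. The step between compound 1 and compound 3 cannot be read, so the 4-iodophenyl group remains unplaced relative to either dihalogenated group, and nothing measured here offers an explanation for the result.

With only these two halogen patterns on the scale, the compounds shown leave open whether any group on this nitrogen can carry the number beyond the scatter, whether that is a plain phenyl, a phenyl bearing a methoxy group or one bearing a carboxylic acid. They also leave open whether a single chlorine on the phenyl ring would read differently from the two halogens of compound 2 and compound 3.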